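Fluoro in Place of Cyano on a Sulfonyl Ring

A few compounds are considered here, and "the series" means these few. Any claim that something is new, unique, unknown or untested is made for them only; others in the source may bear on it.

Compound 2 `COc1ccc(-c2cc(=O)c3c(OC)cc(OC)cc3n2S(=O)(=O)c2ccc(C#N)cc2)cc1` was tested in an ADME assay on BJ cells (Homo sapiens) for antiproliferative activity, with a stated time of 72 h (a higher number here means that more compound is needed for the effect, a lower number that less compound is needed), and gives > 17200 nM, which is a limit of the assay rather than a number. Compound 1 `COc1ccc(-c2cc(=O)c3c(OC)cc(OC)cc3n2S(=O)(=O)c2ccc(C=O)cc2)cc1` likewise gives only a limit, > 34400 nM. Among the measured compounds shown here, the only measured step, a step that the two limits leave unreadable from compound 1 to compound 2, is unreadable and sets no direction. Compound 3 `COc1ccc(-c2cc(=O)c3c(OC)cc(OC)cc3n2S(=O)(=O)c2ccc(F)cc2)cc1` differs from compound 2 by fluoro in place of cyano on an aromatic carbon. Because both known values sit at limits, the limit of > 17200 nM in this assay, at which 1 of the 2 values shown sits, and (the limit of > 34400 nM in this assay, at which 1 of the 2 values shown sits), no size of step can be read. Compound 3 is therefore expected to give roughly 20000 nM, within a range from 5000 nM to 60000 nM. The implied step that the limit leaves unreadable from compound 2 to compound 3 is expected to stay within the scatter.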

Compound 3, half-maximal effective concentration: > 65500 nM
Compound 3 gave a limit, no number (the forecaster's own chance of this, stated with the estimate: 75%); middle value at least 3.2-fold (0.51 log units) away from the limit.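

The steps among compound 1, compound 2 and compound 3 cannot be read, since each value is a limit and not a number. As far as these compounds go, whether formyl, cyano or fluoro needs less compound for the effect stays open.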